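Amide substituent on the piperidine carboxamide: oxetane to oxane

A few compounds are considered here, and "the series" means these few. Any claim that something is new, unique, unknown or untested is made for them only; others in the source may bear on it.

Measured so far:
compound 1 `CCN(CC)S(=O)(=O)c1ccc(S(=O)(=O)N2CCC[C@@H](C(=O)N[C@H]3CC[C@H](OC)CC3)C2)cc1`: 2000 nM
compound 2 `CCN(CC)S(=O)(=O)c1ccc(S(=O)(=O)N2CCC[C@@H](C(=O)NC3COC3)C2)cc1`: 13800 nM

In a functional assay on BXPC-3 cells (Homo sapiens) for inhibition, read by MTT assay, with a stated time of 7 days (a lower number here means a stronger inhibitor, a higher number a weaker inhibitor), compound 1 gives 2000 nM. Among the measured compounds shown here, compound 2 has oxetan-3-yl on the amide-type nitrogen in place of 4-methoxycyclohexyl, and in this assay compound 2 gives 13800 nM, the highest number of the two; the step of a 6.9-fold higher number from compound 1 to compound 2 (0.84 log units; beyond the scatter) is the only measured step.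

Compound 3 `CCN(CC)S(=O)(=O)c1ccc(S(=O)(=O)N2CCC[C@@H](C(=O)NC3CCOCC3)C2)cc1` has not been measured. Its difference from compound 2 is oxan-4-yl in place of oxetan-3-yl on an amide-type nitrogen. For the measured compounds named here, the one measured step bears on it only indirectly: it shows that the group on the amide-type nitrogen matters beyond the scatter, with the six-membered 4-methoxycyclohexyl of compound 1 giving the lower number and the four-membered oxetan-3-yl of compound 2 the higher. Oxan-4-yl is a six-membered ring with one oxygen and without the methoxy of compound 1, so a number between the two measured values is expected. For compound 3 the step of a 3.1-fold lower number from compound 2 to compound 3 (0.49 log units; beyond the scatter) is estimated, a lower number than compound 2. Compound 3 is thus expected to give 4500 nM, with a range from 1500 nM to 12000 nM.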

Compound 3, half-maximal inhibitory concentration: 8570 nM
For compound 3 the middle estimate is 1.9-fold (0.28 log units) below the measured one, within the range that was stated.
By their numbers in this assay, from the lowest: compound 1; then compounds 3 and 2 (each within the scatter of the next).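

In this assay, oxan-4-yl in place of oxetan-3-yl on the amide-type nitrogen gives a 1.6-fold lower number from compound 2 to compound 3 (0.21 log units; within the scatter), so this pair does not separate the four-membered ring from the six-membered ring, each with one hetero atom. Oxan-4-yl in place of 4-methoxycyclohexyl gives a 4.3-fold higher number from compound 1 to compound 3 (0.63 log units; beyond the scatter), which shows that a six-membered ring at this place is not enough to reach the number of compound 1; of the three groups, only 4-methoxycyclohexyl stands apart from the others beyond the scatter. Nothing on hand offers an explanation for these numbers.

Still open, on these data alone, is whether the number of compound 1 goes with its cyclohexyl ring, which has no ring oxygen, or with its methoxy, as compound 1 and compound 3 differ in both features at once. Plain cyclohexyl on the amide-type nitrogen would help to separate these two features, while 4-hydroxycyclohexyl or 4-aminocyclohexyl would test what the methoxy can be replaced by at this place.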